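This account rests on a few compounds, and the source may have more. Where it says the series, first, only, none or still open, it means among the compounds named here.

Measured compounds:
- compound 1 `CC(C)c1cc(C(C)(C)C)cc(-c2cccc(C(F)(F)F)c2)c1CO` gives > 50000 nM in a functional assay on RKE cells for antagonist activity at Vasoactive intestinal polypeptide receptor 1 (Rattus norvegicus), read by HTRF and cAMP accumulation, with stated times of 10 min and 30 min; a lower number here means a stronger inhibitor, a higher number a weaker inhibitor
- compound 2 `CC(C)c1cc(C(C)(C)C)cc(-c2ccc(Cl)cc2)c1CO` gives 290 nM in this assay

The value for compound 1 is a limit of this assay, not a measured number. Going by the values given here, compound 2 therefore holds the only real number among the two, and it stands apart from the other entry, which sits at the limit described by the limit of > 50000 nM in this assay, at which 1 of the 2 values shown sits. Compound 3 `CC(C)c1cc(C(C)(C)C)cc(-c2cccc(Cl)c2)c1CO` has not yet been measured. Its structure keeps everything of compound 2 except one change: 3-chlorophenyl in place of 4-chlorophenyl on an aromatic carbon. The chlorine thus stays on the same ring but moves to a different aromatic carbon, with the same atoms joined differently. Among the compounds with values here, no step between two measured compounds shows what such a move does here, and the only other measured compound, compound 1, carries a trifluoromethyl group instead of chlorine, so it cannot settle the question. The expectation is a loss of potency for compound 3 that goes beyond the scatter, with an 8.6-fold higher number from compound 2 to compound 3 (0.94 log units; beyond the scatter) as the estimated step, though a result within the scatter is not excluded. Compound 3 is expected to give about 2500 nM in this assay, between 400 nM and 30000 nM.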

Compound 3, half-maximal inhibitory concentration: 100 nM
For compound 3 the middle estimate is 25-fold (1.40 log units) above the measured one, outside the stated range (below it).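

In this assay, going by these compounds alone, moving the chlorine so that 3-chlorophenyl replaces 4-chlorophenyl gives a 2.9-fold lower number from compound 2 to compound 3 (0.46 log units; beyond the scatter), a comparison the earlier compounds could not offer, and it shows that the place of the chlorine on this ring alone changes the read-out while the atoms stay the same. Setting chloro in place of trifluoromethyl on an aromatic carbon gives an at least 500-fold lower number from compound 1 to compound 3 (2.69 log units; beyond the scatter), which for the first time compares these two groups in a single place on otherwise identical compounds and shows that the choice of group there matters far more in this set than the move of the chlorine. The value of compound 1 is a limit of the assay and not a measured number: the limit of > 50000 nM in this assay, at which 1 of the 3 values shown sits.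

The compounds shown leave open how a methoxy group or an amine would behave in place of the chlorine on the same aromatic carbon, and whether a trifluoromethyl group would respond to the same move around the ring as chlorine does. What lies behind the difference between the two chlorine positions also stays unknown.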